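Replacing trifluoromethoxy with hydrogen in compound 3

The source may hold more compounds than are shown below. What is called first, only, known or untested is meant among the compounds shown, and "the series" means these compounds.

Measured compounds:
- compound 1 `Clc1ccc(Cn2cc(CCCOc3cccc4cccnc34)nn2)cc1` gives 3.6 ug/mL
- compound 2 `Brc1ccc(Cn2cc(CCCOc3cccc4cccnc34)nn2)cc1` gives 8.4 ug/mL
- compound 3 `FC(F)(F)Oc1ccc(Cn2cc(CCCOc3cccc4cccnc34)nn2)cc1` gives 5 ug/mL

All three values come from a functional assay on PC-3 cells (Homo sapiens) for inhibition, read by sulforhodamine B assay, with a stated time of 48 h (on this read-out lower numbers stand for stronger inhibition of growth and higher numbers for weaker inhibition of growth), and the compounds share one core. Among these numbers, compound 3 (5 ug/mL) lies within the scatter of the other two. The steps that show this are a 1.4-fold higher number from compound 1 to compound 3 (0.14 log units; within the scatter) and a 1.7-fold lower number from compound 2 to compound 3 (0.23 log units; within the scatter). The remaining step, a 2.3-fold higher number from compound 1 to compound 2 (0.37 log units; beyond the scatter), goes beyond the scatter but is only modest.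

The next compound is compound 4 `c1ccc(Cn2cc(CCCOc3cccc4cccnc34)nn2)cc1`, which carries hydrogen in place of trifluoromethoxy on an aromatic carbon. The counted difference is hydrogen in place of trifluoromethoxy on an aromatic carbon. For the measured compounds named here, no measured step removes a group and leaves hydrogen, so the data bear on this change only indirectly, through exchanges of one group for another at that same place. The largest of those exchanges, a 2.3-fold higher number from compound 1 to compound 2 (0.37 log units; beyond the scatter), is modest, so no step beyond the scatter is expected in this assay. The estimated step is a 1.2-fold higher number from compound 3 to compound 4 (0.08 log units; within the scatter) and has no firm direction. From the compounds shown here alone, the expected range is kept wide, as hydrogen is untested. The estimate for compound 4 is 6 ug/mL with 2.5 ug/mL to 15 ug/mL as its expected range.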

Compound 4, concentration for 50% growth inhibition: 16.8 ug/mL
Compound 4: middle estimate off by 2.8-fold (0.45 log units), on the low side; the whole stated range lies below it.
By their numbers in this assay, from the lowest: compounds 1, 3, 2 and 4 (each within the scatter of the next, the first and the last beyond it).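

In this assay, the earlier exchanges of one group for another could not show whether this place, on an aromatic carbon para to a large group, needs a group at all, but the hydrogen compound bears on that: hydrogen in place of trifluoromethoxy gives a 3.4-fold higher number from compound 3 to compound 4 (0.53 log units; beyond the scatter), and hydrogen in place of chloro gives a 4.7-fold higher number from compound 1 to compound 4 (0.67 log units; beyond the scatter), both modest steps towards weaker inhibition of growth. Bromo goes against this pattern, as hydrogen in place of bromo gives a 2.0-fold higher number from compound 2 to compound 4 (0.30 log units; within the scatter), so that pair stays unseparated and the benefit of a group over hydrogen holds for only two of the three groups shown. Nothing on hand explains these steps or the different standing of bromo.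

Still open, from the compounds shown here alone, is how an amine, a carboxylic acid or a methoxy group at this same place would compare with hydrogen and with chloro. Also open, going by these compounds, is whether the modest separation from hydrogen would carry over to any read-out other than this assay, or to a longer chain in the shared core.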